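A few compounds are considered here, and "the series" means these few. Any claim that something is new, unique, unknown or untested is made for them only; others in the source may bear on it.

Measured so far in an ADME assay on HepG2 cells (Homo sapiens) for cytotoxicity, in the presence of a further agent that is not named here (on this read-out lower numbers stand for stronger inhibition and higher numbers for weaker inhibition), all as limits of the assay:
- Compound 1 `Cn1c(Cc2ccccc2C(F)(F)F)nc(C(=O)Nc2ccccc2)c(O)c1=O`: > 100000 nM
- Compound 2 `CC(NC(=O)c1nc(Cc2ccccc2C(F)(F)F)n(C)c(=O)c1O)c1ccccc1`: > 100000 nM
- Compound 3 `Cn1c(Cc2ccccc2C(F)(F)F)nc(C(=O)CCc2ccccc2)c(O)c1=O`: > 100000 nM

Compound 3 gives > 100000 nM, which is a limit and not a number. Within the data shown here, the whole series so far shows (the limit of > 100000 nM in this assay, at which 3 of the 3 values shown sit).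

Compound 4 `Cn1c(Cc2ccccc2C(F)(F)F)nc(C(=O)NCc2ccc(F)cc2)c(O)c1=O` has (4-fluorobenzyl)amino in place of phenethyl on a carbonyl carbon.

The nearest measured changes at that carbonyl carbon are a step that the two limits leave unreadable from compound 1 to compound 3 and a step that the two limits leave unreadable from compound 2 to compound 3. The remaining comparison is a step that the two limits leave unreadable from compound 1 to compound 2. None of these has a readable size, so no change beyond the scatter is expected in this assay. The expected step is a number no higher from compound 3 to compound 4 (the limit leaves the size open). Compound 4 is expected at 100000 nM, with an estimated range of 50000 nM to 200000 nM.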

Compound 4, half-maximal inhibitory concentration: > 100000 nM
Compound 4: no number, only a limit; the forecaster's own chance of this, stated with the estimate: 90%; the middle value lies on the limit itself.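

Compound 4 gives > 100000 nM, a limit and not a number, so its steps from compound 1, compound 2 and compound 3 cannot be read. The compounds shown leave open how these changes at the carbonyl carbon compare in this assay, since every value sits at one limit: the limit of > 100000 nM in this assay, at which 4 of the 4 values shown sit.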